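This account rests on a few compounds, and the source may have more. Where it says the series, first, only, none or still open, it means among the compounds named here.

Three compounds have been measured so far in an ADME assay on Huh-7 cells (Homo sapiens) for cytotoxicity, with a stated time of 72 h; on this read-out higher numbers stand for lower toxicity in this test and lower numbers for higher toxicity in this test:

Compound 1, `COCN(c1ccc2c(c1)S(=O)(=O)N=C(c1c(O)c(-c3cccs3)nn(CCC(C)C)c1=O)N2)S(C)(=O)=O`, gives > 1000 nM, which is a limit of the assay and not a number.
Compound 2, `CC(C)CCn1nc(CC2CCC2)c(O)c(C2=NS(=O)(=O)c3cc(NS(C)(=O)=O)ccc3N2)c1=O`, gives > 33000 nM, again only a limit.
Compound 3, `COC(C)(C)CCn1nc(-c2cccs2)c(O)c(C2=NS(=O)(=O)c3cc(NS(C)(=O)=O)ccc3N2)c1=O`, gives > 33000 nM, also a limit.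

No two of these compounds differ in a single place, so no step between measured compounds can be stated. Compound 3 stands at the limit of > 33000 nM in this assay, at which 2 of the 3 values shown sit, the same position as compound 2, while compound 1 sits at the limit of > 1000 nM in this assay, at which 1 of the 3 values shown sits. Since every result is a limit, no ordering among the three can be drawn from these data.

Compound 4, `CS(=O)(=O)Nc1ccc2c(c1)S(=O)(=O)N=C(c1c(O)c(-c3cccs3)nn(Cc3ccccc3)c1=O)N2`, has not yet been measured. It differs from compound 3 in one respect: phenyl in place of 2-methoxy-2-methylpropyl on a saturated chain carbon bound to an aromatic nitrogen. For the measured compounds named here, no measured step resembles this change, so its size in this assay cannot be read from the series. The expectation is that the step produces no shift beyond the usual scatter and that compound 4 again lands at the limit rather than at a number. Compound 4 is therefore estimated at 40000 nM, expected to lie within 10000 nM to 100000 nM. This estimate is expected to amount to a step that the limit leaves unreadable from compound 3 to compound 4.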

Compound 4, half-maximal cytotoxic concentration: > 1000 nM
Compound 4 ended at the assay's limit; the forecaster's own chance of this, stated with the estimate: 85%; the middle value does not contradict the limit.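

In this assay compound 4 gives > 1000 nM, a limit of the assay and not a number. For the compounds shown here, compound 3 gives > 33000 nM, also only a limit, so no step between these two compounds can be read. The compounds shown leave open whether phenyl in place of 2-methoxy-2-methylpropyl shifts the half-maximal cytotoxic concentration, and where any of the four compounds actually lies.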